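The source may report more compounds than this note shows. Statements on the series, on what has been measured and on what is new or still open speak of the compounds shown alone.

Three compounds share one core and differ only in the group attached at the same carbon of that core. Compound 1 `CCN1CCN(c2nc(Nc3ccc(C(=O)NC4CC(C)(C)N([O])C(C)(C)C4)cc3)ncc2[N+](=O)[O-])CC1` carries a 4-ethylpiperazin-1-yl group there, and in a functional assay on HepG2 cells (Homo sapiens) for antiproliferative activity, read by MTT assay, with a stated time of 48 h (a lower number here means a stronger inhibitor, a higher number a weaker inhibitor), compound 1 gives 56800 nM. Compound 2 `Cc1cc(Nc2nc(Nc3ccc(C(=O)NC4CC(C)(C)N([O])C(C)(C)C4)cc3)ncc2[N+](=O)[O-])n[nH]1` carries a (5-methyl-1H-pyrazol-3-yl)amino group, and in this assay compound 2 gives 37500 nM; the step of a 1.5-fold lower number from compound 1 to compound 2 (0.18 log units; within the scatter) is within the scatter. Compound 3 `CCOC(=O)c1csc(Nc2nc(Nc3ccc(C(=O)NC4CC(C)(C)N([O])C(C)(C)C4)cc3)ncc2[N+](=O)[O-])n1` carries a (4-(ethoxycarbonyl)-1,3-thiazol-2-yl)amino group, and in this assay compound 3 gives 6870 nM, the lowest of the three numbers. The steps of an 8.3-fold lower number from compound 1 to compound 3 (0.92 log units; beyond the scatter) and a 5.5-fold lower number from compound 2 to compound 3 (0.74 log units; beyond the scatter) both lie beyond the scatter, so compound 3 is the strongest inhibitor among the three measured.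

Compound 4 `CCOC(=O)Cc1csc(Nc2nc(Nc3ccc(C(=O)NC4CC(C)(C)N([O])C(C)(C)C4)cc3)ncc2[N+](=O)[O-])n1` keeps the thiazolylamino group of compound 3 and changes only the substituent on it: (ethoxycarbonyl)methyl in place of ethoxycarbonyl on an aromatic carbon. None of the three measured steps touches this substituent; each of them exchanges the whole group on the core, so they give no direct guide to the size of this change. For the measured compounds named here, with no step bearing on it, the expectation for compound 4 is a number close to that of compound 3, as a step of a 1.2-fold higher number from compound 3 to compound 4 (0.07 log units; within the scatter) that stays within the scatter. Compound 4 is therefore estimated at 8000 nM, with a range from 3000 nM to 25000 nM.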

Compound 4, half-maximal inhibitory concentration: 26400 nM
Compound 4: the middle estimate sits 3.3-fold (0.52 log units) below what was measured; measured number outside the range, above it.
By their numbers in this assay, from the lowest: compound 3; then compounds 4, 2 and 1 (each within the scatter of the next, the first and the last beyond it).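

For the compounds shown here, the substituent on the thiazole ring turns out to matter on its own, which the earlier steps could not show, since each of them exchanged the whole group on the core: in this assay the change from ethoxycarbonyl to (ethoxycarbonyl)methyl gives a 3.8-fold higher number from compound 3 to compound 4 (0.58 log units; beyond the scatter) and so lies beyond the scatter. The gain of the thiazolylamino compounds therefore depends on this substituent, for a 1.4-fold lower number from compound 2 to compound 4 (0.15 log units; within the scatter) stays within the scatter, and a 2.2-fold lower number from compound 1 to compound 4 (0.33 log units; beyond the scatter) is smaller than an 8.3-fold lower number from compound 1 to compound 3 (0.92 log units; beyond the scatter) seen with the ethoxycarbonyl group. Nothing given here explains why the two esters differ.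

The two thiazole compounds cannot tell whether the difference follows from the added methylene link or would also appear with another group on this aromatic carbon, such as a carboxylic acid, a primary amide or a methyl group. Nor can they tell whether a longer chain, such as 2-(ethoxycarbonyl)ethyl, would carry the change further or whether the number would return towards that of compound 3.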